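Amino for hydrogen on the shared core: compound 2 to 4

This account rests on a few compounds, and the source may have more. Where it says the series, first, only, none or still open, it means among the compounds named here.

Compound 2 `ClCc1ccccc1Cn1cnc2c(Cl)ncnc21` stands second highest of the three numbers measured in a functional assay on PC-3 cells (Homo sapiens) for cytotoxicity, read by sulforhodamine B assay, with a stated time of 48 h (on this read-out higher numbers stand for lower toxicity in this test and lower numbers for higher toxicity in this test), where compound 2 gives 53700 nM. Its nearest neighbour, compound 3 `ClCc1cccc(Cn2cnc3ncnc(Cl)c32)c1`, gives 63100 nM, within the scatter of compound 2. For the measured compounds named here, compound 1 `ClCc1ccccc1Cn1cnc2c(Cl)nc(Cl)nc21`, which carries a chloro at the position in question, gives 5120 nM; the step of a 10-fold higher number from compound 1 to compound 2 (1.02 log units; beyond the scatter) is the only measured step bearing on the change at hand. Compound 4 `Nc1nc(Cl)c2ncn(Cc3ccccc3CCl)c2n1` differs from compound 2 by amino in place of hydrogen on an aromatic carbon, sitting between two ring nitrogen atoms, meta to a chloro group. That step concerned chloro, not amino, so its size transfers only loosely; a small shift toward lower numbers in this assay is expected, plausibly within the scatter, as a 1.5-fold lower number from compound 2 to compound 4 (0.19 log units; within the scatter). Compound 4 is therefore estimated at 35000 nM, with a range from 9000 nM to 130000 nM.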

Compound 4, concentration lethal to 50% of the cells: > 100000 nM
Compound 4 ended at the assay's limit; the forecaster's own chance of this, stated with the estimate: 5%; middle value at least 2.8-fold (0.45 log units) from the limit.
By their numbers in this assay, from the lowest: compound 1; then compounds 2 and 3 (each within the scatter of the next). At a limit, above all of these: compound 4.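

Compound 4 stands at a limit of this assay, not at a number: the limit of > 100000 nM in this assay, at which 1 of the 4 values shown sits. Amino in place of chloro on this carbon, between two ring nitrogen atoms, gives an at least 19-fold higher number from compound 1 to compound 4 (1.29 log units; beyond the scatter), while amino in place of hydrogen gives an at least 1.8-fold higher number from compound 2 to compound 4 (0.27 log units; that floor lies within the scatter), a floor that does not separate the two groups. Among hydrogen, amino and chloro at this position, only chloro goes with a clearly lower number.

As far as these compounds go, how far amino lies from hydrogen stays open, as compound 4 has no exact number. Also open, from the compounds shown here alone, is how a bromo, a methyl or a methoxy group would read on this carbon.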